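Chloro to fluoro on the benzyl ring: compound 4

The source may report more compounds than this note shows. Statements on the series, on what has been measured and on what is new or still open speak of the compounds shown alone.

Measured so far:
compound 1 `COc1cc(-c2nnc(SCc3ccccc3[N+](=O)[O-])o2)ccc1O`: 9600 nM
compound 2 `COc1cc(-c2nnc(SCc3cccc([N+](=O)[O-])c3)o2)ccc1O`: 16000 nM
compound 3 `COc1cc(-c2nnc(SCc3ccc(Cl)cc3)o2)ccc1O`: 11100 nM

In a functional assay on cells (T-cell, Mus musculus, strain BALB/c) for inhibition, read by MTT assay, with stated times of 24 h and 72 h (on this read-out lower numbers stand for stronger inhibition and higher numbers for weaker inhibition), compound 3 gives 11100 nM, the second highest of the three numbers. Its gap to compound 1 and its gap to compound 2 both lie within the scatter, so the three measured compounds cannot be ordered on these values. Compound 4 `COc1cc(-c2nnc(SCc3ccc(F)cc3)o2)ccc1O` differs from compound 3 by fluoro in place of chloro on an aromatic carbon. Going by the values given here, no measured pair shows this same change, so nothing fixes its size or direction. With chloro and nitro variants all within the scatter of one another, the step of a 1.1-fold higher number from compound 3 to compound 4 (0.05 log units; within the scatter) is expected to stay within the scatter as well. Compound 4 is accordingly estimated at 12500 nM, with a range from 6000 nM to 26000 nM.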

Compound 4, half-maximal inhibitory concentration: 8190 nM
Compound 4: the middle estimate sits 1.5-fold (0.18 log units) above what was measured, and the stated range covers the measured number.
By their numbers in this assay, from the lowest: compounds 4, 1, 3 and 2 (each within the scatter of the next).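

In this assay the series now has its first single-place comparison, with fluoro in place of chloro giving a 1.4-fold lower number from compound 3 to compound 4 (0.13 log units; within the scatter). On an aromatic carbon para to a large group, this change therefore produces no difference that can be told apart from the scatter. Nothing available explains the result or bears on it.

From the compounds shown here alone, whether an amine or a carboxylic acid at this same place would move the number beyond the scatter remains open. Also open, going by these compounds, is whether any change to the shared core would do so.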